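Fluorine at Three Positions Across a Shared Amide Scaffold

The source may hold more compounds than are shown below. What is called first, only, known or untested is meant among the compounds shown, and "the series" means these compounds.

Compound 1, `Cn1ccc2c(Oc3ccc(NC(=O)c4cc5cccnc5n(-c5ccc(Cl)cc5)c4=O)cc3)ncnc21`, was tested in a functional assay on HeLa cells (Homo sapiens) for cytotoxicity, read by MTT assay, with a stated time of 72 h (on this read-out higher numbers stand for weaker inhibition and lower numbers for stronger inhibition), where compound 1 gives 49900 nM. Compound 2, `Cn1ccc2c(Oc3ccc(NC(=O)c4cc5cccnc5n(-c5ccc(Cl)cc5)c4=O)cc3F)ncnc21`, carries one change relative to compound 1: fluoro in place of hydrogen on an aromatic carbon. In this assay compound 2 gives 43900 nM, and the step is a 1.1-fold lower number from compound 1 to compound 2 (0.06 log units; within the scatter).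

Compound 3, `O=C(Nc1ccc(Oc2ncnc3[nH]ccc23)c(F)c1)c1cc2cccnc2n(-c2ccccc2)c1=O`, has a different core; how the core of compound 3 differs from the core of compound 1 is not broken down here. In this assay compound 3 gives 36900 nM. The values of compound 1, compound 2 and compound 3 all lie within the usual scatter of one another.

Compound 4, `O=C(Nc1ccc(Oc2ncnc3[nH]ccc23)c(F)c1)c1cc2cccnc2n(-c2ccc(F)cc2)c1=O`, is not yet measured. It differs from compound 3 by fluoro in place of hydrogen on an aromatic carbon. Within the data shown here, this is the same kind of change as the one from compound 1 to compound 2, but not the same: there the fluorine sits ortho to a large group and meta to a large group, here it sits para to a large group.

For compound 4 the expected step is a 1.1-fold lower number from compound 3 to compound 4 (0.02 log units; within the scatter), an expectation that rests on the small step of a 1.1-fold lower number from compound 1 to compound 2 (0.06 log units; within the scatter). Compound 4 is therefore estimated at 35000 nM, expected between 15000 nM and 80000 nM.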

Compound 4, half-maximal inhibitory concentration: 3720 nM
Compound 4: the middle estimate sits 9.4-fold (0.97 log units) above what was measured; the whole stated range lies above it.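

Changing phenyl to 4-fluorophenyl gives a 9.9-fold lower number from compound 3 to compound 4 (1.00 log units; beyond the scatter) in this assay, so on this core a single fluoro group goes with a clear drop in the number. The same kind of change therefore did not carry over at the same size from one core to the other: the same change on two cores in this assay, a 1.1-fold lower number (0.06 log units; within the scatter) from compound 1 to compound 2 and a 9.9-fold lower number (1.00 log units; beyond the scatter) from compound 3 to compound 4, 8.7-fold (0.94 log units) apart, beyond the scatter of two such steps. This does not show why the steps differ, since each rests on one pair of compounds and the fluoro sits at a different place in each, so the core and the place of the fluoro cannot be told apart as the source of the gap.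

On these data alone, it remains open whether 4-fluorophenyl would give a step of similar size on the core of compound 1, which would separate those two explanations. As far as these compounds go, it is also open whether a methoxy group or an amine in place of the fluoro on compound 4 would keep the lower number.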